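Fluoro for methyl on the triazole aryl of a spirooxindole

The source may hold more compounds than are shown below. What is called first, only, known or untested is meant among the compounds shown, and "the series" means these compounds.

Compound 2 `Cc1ccc(-n2nncc2CN2C(=O)C3(C(C#N)=C(N)Oc4c3c3nc5ccccc5nc3c3ccccc43)c3ccccc32)cc1Cl` shares its core with compound 1 `Cc1ccc(-n2nncc2CN2C(=O)C3(C(C#N)=C(N)Oc4c3c3nc5ccccc5nc3c3ccccc43)c3ccccc32)c(C)c1`; it carries a 3-chloro-4-methylphenyl in place of the 2,4-dimethylphenyl on the aromatic nitrogen. In a functional assay on HCT-116 cells (Homo sapiens) for antiproliferative activity, read by MTT assay, with a stated time of 48 h (on this read-out lower numbers stand for stronger inhibition and higher numbers for weaker inhibition), compound 1 reaches only the limit > 50000 nM. In this assay compound 2 likewise reaches only the limit > 50000 nM. The step from compound 1 to compound 2 is therefore a step that the two limits leave unreadable from compound 1 to compound 2, and both values sit at the limit of > 50000 nM in this assay, at which 2 of the 2 values shown sit. Compound 3 `N#CC1=C(N)Oc2c(c3nc4ccccc4nc3c3ccccc23)C12C(=O)N(Cc1cnnn1-c1ccc(F)c(Cl)c1)c1ccccc12` is compound 2 with fluoro in place of methyl on an aromatic carbon. Among the measured compounds shown here, the only measured step, from compound 1 to compound 2, gives no readable size, so the change to compound 3 has no measured counterpart and no direction can be read from it. Compound 3 is therefore expected to stay at the same limit, with a step of a number no higher from compound 2 to compound 3 (the limit leaves the size open) meaning no change beyond the scatter. The estimate for compound 3 is 50000 nM, within 15000 nM to 100000 nM.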

Compound 3, half-maximal inhibitory concentration: > 50000 nM
Compound 3: a limit, no number; the forecaster's own chance of this, stated with the estimate: 80%; the middle value lies on the limit itself.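

In this assay, among the compounds shown here, compound 3 gives > 50000 nM and this value is a limit of the assay, so no step among compound 1, compound 2 and compound 3 can be read. The compounds shown leave open whether any of these aryl groups on the triazole changes antiproliferative activity at all.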